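Phenyl in Place of Methyl on a Selenium-Containing Core

This account rests on a few compounds, and the source may have more. Where it says the series, first, only, none or still open, it means among the compounds named here.

Compound 1 `COc1ccc(/C=N/N(C(C)=O)c2nc(-c3ccccc3)c[se]2)cc1`: > 62700 nM, a limit of the assay.
Compound 2 `Cc1c[se]c(NNC(=O)c2ccccc2)n1`: > 89200 nM, a limit of the assay.

Both compounds were tested in a functional assay on DU-145 cells (Homo sapiens) for cytotoxicity, read by XTT assay, with a stated time of 72 h; on this read-out higher numbers stand for weaker inhibition and lower numbers for stronger inhibition. Compound 2 stands at a limit of the assay and not at a number, and the same holds for compound 1 (the limit of > 62700 nM in this assay, at which 1 of the 2 values shown sits, (the limit of > 89200 nM in this assay, at which 1 of the 2 values shown sits)). Among the measured compounds shown here, no step between two measured compounds can be drawn from these two limits. Compound 3 `O=C(NNc1nc(-c2ccccc2)c[se]1)c1ccccc1` has not yet been measured; it differs from compound 2 in one place: phenyl in place of methyl on an aromatic carbon. Compound 1 carries a phenyl at that place on the same core and gives only a limit in this assay. The step from compound 2 to compound 3 is therefore expected to be a step that the limit leaves unreadable from compound 2 to compound 3, which is no change beyond the usual scatter. Compound 3 is expected to give about 90000 nM, within a range of 30000 nM to 200000 nM, most likely again reported only as a limit.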

Compound 3, half-maximal inhibitory concentration: > 73000 nM
Compound 3: only a limit was reported; the forecaster's own chance of this, stated with the estimate: 80%; the middle value lies beyond the limit too.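

Compound 2 and compound 3 both stand at limits of the assay and not at numbers, so the step between them cannot be read. The compounds shown leave open whether phenyl in place of methyl changes the result in this assay at all: none of them yields a number.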